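This account rests on a few compounds, and the source may have more. Where it says the series, first, only, none or still open, it means among the compounds named here.

Working notes on the series. Compound 1 `CCO/N=C/Nc1cc(Cl)cc(Cl)c1` is the simplest member; in a physicochemical assay for lipophilicity, measured as octanol-water partition (a higher number here means a more lipophilic compound, a lower number a more polar compound), compound 1 gives 3. Compound 2 `CCCCc1c(Cl)cc(N/C=N/OCC)cc1Cl` carries butyl in place of hydrogen on an aromatic carbon of the shared core, and in this assay compound 2 gives 5.6; the step is a number 2.60 log units higher from compound 1 to compound 2 (beyond the scatter). Compound 3 `C#CCc1c(Cl)cc(N/C=N/OCCC)cc1Cl` has its own ring substituent and a propoxy chain; in this assay compound 3 gives 4, the second highest of the three numbers, above compound 1 and below compound 2, both gaps beyond the scatter.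

Compound 4 `C#CCc1c(Cl)cc(N/C=N/OCCCl)cc1Cl` differs from compound 3 only in chloro in place of methyl on a saturated chain carbon, two bonds along the chain from an oxygen. For the measured compounds named here, no measured step touches the chain; the single step on record, hydrogen to butyl on the ring, concerns a different kind of change and gives no direct guide. The exchange is one heavy atom for one heavy atom with no change in donor or acceptor count, so the step expected in this assay is within the scatter, in either direction. The estimate for compound 4 is 4, with range 3.5 to 4.5. The step this estimate implies is no change at the digits printed from compound 3 to compound 4 (within the scatter), an expectation only.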

Compound 4, partition coefficient: 3.7
Beside the measured number, compound 4's estimate is 0.30 log units above it, and the stated range covers the measured number.
By their numbers in this assay, from the lowest: compound 1; then compounds 4 and 3 (each within the scatter of the next); then compound 2.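

In this assay, for the compounds shown here, the step is a number 0.30 log units lower from compound 3 to compound 4 (within the scatter) for chloro in place of methyl on a saturated chain carbon, two bonds along the chain from an oxygen, the first step on record at the chain rather than on an aromatic carbon. Going by these compounds alone, the only earlier step, a number 2.60 log units higher from compound 1 to compound 2 (beyond the scatter) for butyl in place of hydrogen, lay beyond the scatter, whereas propoxy and 2-chloroethoxy cannot be told apart in this assay on this core. Nothing on record bears on why this exchange gives this result.

Open, from the compounds shown here alone, is whether other groups at this chain position, such as a hydroxyl, an amine or a carboxylic acid in place of the chloro, would also stay within the scatter. Also open, going by these compounds, is whether a longer chain ending in chloro would read the same as compound 4.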